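A few compounds are considered here, and "the series" means these few. Any claim that something is new, unique, unknown or untested is made for them only; others in the source may bear on it.

In an ADME assay on Caco-2 cells (Homo sapiens) for permeability, read by LC-MS, in the apical to basolateral direction, with a stated time of 2 h (on this read-out lower numbers stand for lower permeability and higher numbers for higher permeability), compound 1 (`COc1cc(C(=O)N2CCC(C)(C)C2)cc2nc(NCc3cccc(Cl)c3)oc12`) is recorded as "not determined" (no result reported) and so offers no single number from which to start. Among the compounds with values here, the only reading at hand belongs to compound 2 (`COc1cc(C(=O)N2CCC(O)C(C)C2)cn2nc(NCc3cccc(Cl)c3)nc12`), which gives 71 nm/s in this assay but differs from compound 1 in more than one place, so the two form no clean step.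

Compound 3 (`COc1cc(C(=O)N2CC(C)C(O)CC2CCO)cc2nc(NCc3cccc(Cl)c3)oc12`) has yet to be measured. It keeps the core of compound 1 and changes one group on a carbonyl carbon, where 4-hydroxy-2-(2-hydroxyethyl)-5-methylpiperidin-1-yl stands in place of 3,3-dimethylpyrrolidin-1-yl (4-hydroxy-2-(2-hydroxyethyl)-5-methylpiperidin-1-yl in place of 3,3-dimethylpyrrolidin-1-yl on a carbonyl carbon).

Without a number for compound 1, the size of this step in this assay cannot be read from the data. Going by these compounds, a move toward lower numbers is expected, though its extent remains open. The nearest anchor is compound 2 at 71 nm/s and, as a hydroxylated amide too, compound 3 is expected to sit in the same low region or somewhat under it. For compound 3 the estimated value is 40 nm/s with an expected range from 12 nm/s to 130 nm/s in this measurement.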

Compound 3, apparent permeability: 9.4 nm/s
Compound 3: the middle estimate sits 4.3-fold (0.63 log units) above what was measured, outside the stated range (below it).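

Within the data shown here, no step from compound 1 to compound 3 can be read in this assay as compound 3 gives 9.4 nm/s while compound 1 is recorded as "not determined" (no result reported) and offers no number to compare. The compounds shown leave open what placing 4-hydroxy-2-(2-hydroxyethyl)-5-methylpiperidin-1-yl for 3,3-dimethylpyrrolidin-1-yl does on its own, and no supporting data bear on this result.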